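This account rests on a few compounds, and the source may have more. Where it says the series, first, only, none or still open, it means among the compounds named here.

Compound 1 `O=C(Nc1ccc(Oc2ccnc3[nH]ccc23)cc1)c1nn(-c2ccc(Br)cc2)ccc1=O`: 4280 nM
Compound 2 `O=C(Nc1ccc(Oc2ccnc3[nH]ccc23)c(F)c1)c1nn(-c2ccc(Br)cc2)ccc1=O`: 68000 nM
Compound 3 `O=C(Nc1ccc(Oc2ccnc3[nH]ccc23)c(F)c1)c1nn(-c2ccc(Cl)c(C(F)(F)F)c2)ccc1=O`: 11900 nM

These numbers come from a functional assay on HepG2 cells (Homo sapiens) for cytotoxicity, read by MTT assay, with a stated time of 72 h; on this read-out higher numbers stand for weaker inhibition and lower numbers for stronger inhibition. Compound 2 gives the highest of the three, so among these it is the weakest inhibitor of cell growth; the two measured steps are a 16-fold higher number from compound 1 to compound 2 (1.20 log units; beyond the scatter) and a 5.7-fold lower number from compound 2 to compound 3 (0.76 log units; beyond the scatter), both beyond the scatter. Compound 4 `Cn1ccc2c(Oc3ccc(NC(=O)c4nn(-c5ccc(Br)cc5)ccc4=O)cc3F)ccnc21` differs from compound 2 by a single change: methyl in place of hydrogen on an aromatic nitrogen. Neither measured step touches this part of the molecule: one alters a ring carbon elsewhere, the other swaps a whole aryl group, so nothing directly bears on this change. For the measured compounds named here, with no guiding step, the expected outcome is no change beyond the scatter, a 1.4-fold lower number from compound 2 to compound 4 (0.13 log units; within the scatter). Compound 4 is therefore estimated at 50000 nM, within 15000 nM to 150000 nM.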

Compound 4, half-maximal inhibitory concentration: > 60000 nM
Compound 4 ended at the assay's limit (the forecaster's own chance of this, stated with the estimate: 20%); at least 1.2-fold (0.07 log units) between middle value and limit.
By their numbers in this assay, from the lowest: compound 1; then compound 3; then compound 2.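

Compound 4 reached a limit of the assay, > 60000 nM, so its step from compound 2 cannot be read: the limit of > 60000 nM in this assay, at which 1 of the 4 values shown sits. The compounds shown leave open whether methyl in place of hydrogen on this aromatic nitrogen changes the number at all.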